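The source may report more compounds than this note shows. Statements on the series, on what has been measured and on what is new or still open speak of the compounds shown alone.

In an ADME assay on a cell-free system (plasma, Homo sapiens) for protein binding, at pH 7.4, compound 1, with structure `O=C(NCc1ccc(F)cc1)c1ncc2cccnc2c1O`, gives 99.2%. Compound 2, with structure `CCN1CC(c2nc(C(=O)NCc3ccc(F)cc3S(C)(=O)=O)c(O)c3ncccc23)CC1=O`, gives 96% in this assay. Going by the values given here, of the two compounds measured so far, compound 2 has the larger unbound fraction; its only neighbour, compound 1, has a lower unbound fraction by a margin beyond the usual scatter of the measurement. Compound 3, with structure `CN1CC(c2nc(C(=O)NCc3ccc(F)cc3S(C)(=O)=O)c(O)c3ncccc23)CC1=O`, has not yet been measured. It differs from compound 2 in a single place: hydrogen in place of methyl on a saturated chain carbon bound to an amide-type nitrogen in a ring. Among the compounds with values here, no measured pair shows this kind of change, so there is no direct comparison to draw on. Removing one carbon from a short saturated chain is a small change, and the step a 1.3-fold higher unbound fraction from compound 2 to compound 3 (0.10 log units; within the scatter) is expected to stay within the scatter, with the bound fraction at most slightly lower. Compound 3 is therefore estimated at 95%, within a range from 91% to 97.5%.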

Compound 3, plasma protein binding in the plasma assay: 97%
Estimate against measurement, compound 3: 1.7-fold (0.22 log units) (unbound fraction) above, and the stated range covers the measured number.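

In the plasma assay, hydrogen in place of methyl on a saturated chain carbon bound to an amide-type nitrogen in a ring gives a 1.3-fold lower unbound fraction from compound 2 to compound 3 (0.12 log units; within the scatter), so this first pair at this position shows that going from 1-ethyl-5-oxopyrrolidin-3-yl to 1-methyl-5-oxopyrrolidin-3-yl does not shift binding beyond the scatter. In a physicochemical assay for lipophilicity, at pH 7.4 (on this read-out higher numbers stand for higher lipophilicity and lower numbers for lower lipophilicity), compound 2 gives 1.9 and compound 3 gives 1.6, a step that also lies within the scatter. Nothing shown here explains either result.

With only ethyl and methyl at this place, the compounds leave open how a longer chain such as butyl would behave in the plasma assay. The same holds for a chain carrying an amine or a carboxylic acid at its end.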